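Fluoro Removal on a Nitrophenyl Ring in Two Cores

The source may hold more compounds than are shown below. What is called first, only, known or untested is meant among the compounds shown, and "the series" means these compounds.

Measured compounds:
Compound 1, `CC(C)(C)OC(=O)CCC(Nc1ccc(CN(CCCc2c(N)nc(N)nc2O)c2cc(F)cc(F)c2[N+](=O)[O-])cc1)C(=O)OC(C)(C)C`, gives in a functional assay on CCRF-CEM cells (Homo sapiens) for cytotoxicity, in the absence of a further agent (a lower number here means a stronger inhibitor, a higher number a weaker inhibitor), a reading of 13000 nM.
Compound 2, `Nc1nc(N)c(CCCN(Cc2ccc(NC(CCC(=O)O)C(=O)O)cc2)c2cc(F)cc(F)c2[N+](=O)[O-])c(O)n1`, gives in this assay only a limit of the assay, > 100000 nM.
Compound 3, `Nc1nc(N)c(CCCN(Cc2ccc(NC(CCC(=O)O)C(=O)O)cc2)c2cc(F)ccc2[N+](=O)[O-])c(O)n1`, gives in this assay likewise only a limit of the assay, > 100000 nM.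

Compound 1 is the only one of the three that returns a number; the other two sit at a limit. Compound 1 and compound 2 differ in their cores, and that difference is not broken down here.

From compound 2 to compound 3 the change is hydrogen in place of fluoro on an aromatic carbon. Its effect in this assay is a step that the two limits leave unreadable from compound 2 to compound 3; the size cannot be read because the limit of > 100000 nM in this assay, at which 2 of the 3 values shown sit, bounds both values.

The unmeasured compound 4, `CC(C)(C)OC(=O)CCC(Nc1ccc(CN(CCCc2c(N)nc(N)nc2O)c2cc(F)ccc2[N+](=O)[O-])cc1)C(=O)OC(C)(C)C`, carries the same change on the core of compound 1: hydrogen in place of fluoro on an aromatic carbon. The surroundings of the place are the same in both pairs word for word, so this is the same change, not merely the same kind. Since the measured pair gives no readable size, the expectation for compound 4 rests on the reading of compound 1 in this assay, 13000 nM, and on a step from compound 1 to compound 4 of about a 1.2-fold higher number from compound 1 to compound 4 (0.06 log units; within the scatter), estimated to stay within the usual scatter. Compound 4 is therefore expected to give about 15000 nM, between 5000 nM and 45000 nM.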

Compound 4, half-maximal inhibitory concentration: 8700 nM
Beside the measured number, compound 4's estimate is 1.7-fold (0.24 log units) above it, within the range that was stated.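

On the core of compound 1, the change from 3,5-difluoro-2-nitrophenyl to 5-fluoro-2-nitrophenyl gives in this assay a 1.5-fold lower number from compound 1 to compound 4 (0.17 log units; within the scatter), a step within the usual scatter, so on this core hydrogen in place of fluoro leaves no readable mark. On the core of compound 2 the same change cannot be read, and the two steps cannot be set side by side, because both of its values are bound by a single limit of the assay: the limit of > 100000 nM in this assay, at which 2 of the 4 values shown sit. The series therefore offers one readable pair on one core, which does not show that the change behaves alike on the two cores, and it gives no ground for a pattern beyond compound 1 and compound 4.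

The compounds shown leave open what a chlorine atom or a methoxy group in place of the lost fluoro would give in this assay on the core of compound 1, and whether removing the remaining fluoro would read any differently there. They also leave open how a nitrile or an amine in place of the nitro group would read on either core.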